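Bromo in place of chloro on compound 2

The source may report more compounds than this note shows. Statements on the series, on what has been measured and on what is new or still open speak of the compounds shown alone.

Compound 1 `CC(=O)Oc1cc(C)c(Cl)c2c1C(=O)C=CC2=O`: 25500 nM
Compound 2 `Cc1cc(O)c2c(c1Cl)C(=O)C=CC2=O`: 29500 nM
Compound 3 `CCOc1c(C)cc(Cl)c2c1C(=O)C=CC2=O`: 26200 nM

In a functional assay on DU-145 cells (Homo sapiens) for cytotoxicity, read by XTT assay, with a stated time of 24 h (on this read-out higher numbers stand for weaker inhibition and lower numbers for stronger inhibition), compound 2 stands level with the other two compounds, its value lying within the scatter of both. Compound 4 `Cc1cc(O)c2c(c1Br)C(=O)C=CC2=O` has bromo in place of chloro on an aromatic carbon. Going by the values given here, the only measured step, a 1.2-fold higher number from compound 1 to compound 2 (0.06 log units; within the scatter), concerns a different change, hydrogen in place of acetyl on an oxygen on an aromatic ring. Among the compounds with values here, no measured pair exchanges chloro for bromo, so no step beyond the scatter is expected in this assay. The expected step is a 1.1-fold lower number from compound 2 to compound 4 (0.04 log units; within the scatter). Compound 4 is estimated at 27000 nM. The expected range for compound 4 runs from 14000 nM to 50000 nM.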

Compound 4, half-maximal inhibitory concentration: 46300 nM
Compound 4: the middle estimate sits 1.7-fold (0.23 log units) below what was measured; the measured number falls inside the stated range.
By their numbers in this assay, from the lowest: compounds 1, 3, 2 and 4 (each within the scatter of the next).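

In this assay, bromo in place of chloro on this aromatic carbon, para to a hydroxy group and ortho to a methyl group, gives a 1.6-fold higher number from compound 2 to compound 4 (0.20 log units; within the scatter). Going by these compounds alone, the earlier compounds all carried chloro, so this is the first exchange read at this place, and it does not separate the two halogens on this read-out. Nothing measured here offers an explanation for the result. The compounds shown leave open whether an amine or a carboxylic acid on this carbon would give a step beyond the scatter.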